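Benzyl in Place of Methoxyphenoxy: an Expected Potency

The source may report more compounds than this note shows. Statements on the series, on what has been measured and on what is new or still open speak of the compounds shown alone.

Of the compounds shown here, three built on a shared core have been measured in an assay for inhibition of Thromboxane-A synthase (Homo sapiens), using microsomes; on this read-out higher numbers stand for weaker inhibition and lower numbers for stronger inhibition. Compound 1 `O=C(O)CC/C=C\CC1COC(c2ccccc2Cl)OC1c1cccnc1` gives 48 nM in this assay, compound 2 `O=C(O)CC/C=C\CC1COC(c2cccc3ccccc23)OC1c1cccnc1` gives 40 nM, and compound 3 `COc1ccccc1OC(C)(C)C1OCC(C/C=C\CCC(=O)O)C(c2cccnc2)O1` gives 60 nM. Within the data shown here, the only step between two of them that differs in one place, a 1.2-fold lower number from compound 1 to compound 2 (0.08 log units; within the scatter), puts naphthalen-1-yl in place of 2-chlorophenyl on a saturated ring carbon. Compound 3 shows the highest of the three numbers, yet its distances to compound 1 and to compound 2 both lie within the scatter, so the three stand together.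

Compound 4 `CC(C)(Cc1ccccc1)C1OCC(C/C=C\CCC(=O)O)C(c2cccnc2)O1` differs from compound 3 by benzyl in place of 2-methoxyphenoxy on a saturated chain carbon bound to two saturated chain carbons and a saturated ring carbon. Among the measured compounds shown here, no measured step touches this saturated chain carbon; the step from compound 1 to compound 2 concerns a different place, and its size stayed within the scatter. The data therefore offer no ground for a shift in either direction, and the number for compound 4 is expected to stay close to that of compound 3, with a 1.1-fold lower number from compound 3 to compound 4 (0.04 log units; within the scatter) expected to remain within the scatter. Compound 4 is estimated at 55 nM in this assay, with a range from 20 nM to 150 nM.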

Compound 4, half-maximal inhibitory concentration: 12 nM
Estimate against measurement, compound 4: 4.6-fold (0.66 log units) above; measured number below the stated range.
By their numbers in this assay, from the lowest: compound 4; then compounds 2, 1 and 3 (each within the scatter of the next).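

Among these compounds, the group on this saturated chain carbon does bear on the read-out: in this assay, benzyl in place of 2-methoxyphenoxy gives a 5.0-fold lower number from compound 3 to compound 4 (0.70 log units; beyond the scatter), a step beyond the scatter, whereas the earlier compounds all stood within it. The same separation appears against the other two compounds, with 1-benzyl-1-methylethyl in place of naphthalen-1-yl on a saturated ring carbon giving a 3.3-fold lower number from compound 2 to compound 4 (0.52 log units; beyond the scatter) and 1-benzyl-1-methylethyl in place of 2-chlorophenyl giving a 4.0-fold lower number from compound 1 to compound 4 (0.60 log units; beyond the scatter), so compound 4 stands apart from all three. The change swaps a group of 9 heavy atoms and 2 hydrogen-bond acceptors for one of 7 heavy atoms and 0 hydrogen-bond acceptors, but nothing at hand accounts for the stronger inhibition.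

The compounds shown leave open whether the stronger inhibition follows from the presence of benzyl itself or from the loss of the methoxy group and the oxygen that joins the aromatic ring to the chain, a question that unsubstituted phenoxy on the same carbon would address. They also leave open how a longer chain such as 2-phenylethyl, or an amine such as benzylamino, would read at this place.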